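Swapping Chloro for Bromo in a Second Setting

A few compounds are considered here, and "the series" means these few. Any claim that something is new, unique, unknown or untested is made for them only; others in the source may bear on it.

Measured compounds:
- Compound 1, `O=C(/C(=C\c1ccc(Cl)cc1)S(=O)(=O)c1ccc(Br)cc1)c1ccc(Br)cc1`: 50000 nM
- Compound 2, `O=C(/C(=C\c1ccc(Br)cc1)S(=O)(=O)c1ccc(Br)cc1)c1ccc(Br)cc1`: 10000 nM
- Compound 3, `O=C(/C(=C\c1ccc(Cl)c([N+](=O)[O-])c1)Sc1ccc(Br)cc1)c1ccc(Br)cc1`: 10000 nM

Of the compounds shown here, three have been tested in a functional assay on DU-145 cells (Homo sapiens) for inhibition, read by trypan blue exclusion, with a stated time of 96 h; a higher number here means a weaker inhibitor of growth, a lower number a stronger inhibitor of growth. Compound 1 gives 50000 nM, and compound 2, with bromo in place of chloro on an aromatic carbon, gives 10000 nM; that change is bromo in place of chloro on an aromatic carbon, and the step is a 5.0-fold lower number from compound 1 to compound 2 (0.70 log units; beyond the scatter). Compound 3 gives 10000 nM in this assay, level with compound 2 at the digits shown, so no order between those two can be claimed. The difference between the core of compound 3 and the core of compound 1 is not broken down here.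

Compound 4, `O=C(/C(=C\c1ccc(Br)c([N+](=O)[O-])c1)Sc1ccc(Br)cc1)c1ccc(Br)cc1`, has not yet been measured. Compared with compound 3, it carries the change (bromo in place of chloro on an aromatic carbon). Among the measured compounds shown here, this is the same kind of change as the one from compound 1 to compound 2, but not the same: here the place is ortho to a nitro group, which the earlier place was not. As far as these compounds go, whether bromo for chloro behaves alike in this second setting is unknown from a single prior example. For the measured compounds named here, an estimated step of a 2.5-fold lower number from compound 3 to compound 4 (0.40 log units; beyond the scatter) seems reasonable for compound 4, somewhat smaller than the earlier one because a 5.0-fold lower number from compound 1 to compound 2 (0.70 log units; beyond the scatter) is the only guide and its place differs. Compound 4 is therefore expected at about 4000 nM, between 1500 nM and 10000 nM.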

Compound 4, concentration for 50% growth inhibition: 1000 nM
Compound 4: middle estimate off by 4.0-fold (0.60 log units), on the high side, outside the stated range (below it).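

In this assay, putting bromo in place of chloro on an aromatic carbon, here ortho to a nitro group, gives a 10-fold lower number from compound 3 to compound 4 (1.00 log units; beyond the scatter). Set beside the same swap on the other core, the two steps point the same way and cannot be told apart in size: the same change on two cores in this assay, a 5.0-fold lower number (0.70 log units; beyond the scatter) from compound 1 to compound 2 and a 10-fold lower number (1.00 log units; beyond the scatter) from compound 3 to compound 4, 2.0-fold (0.30 log units) apart, within the scatter of two such steps. So in these two pairs the swap carries from one core to the other with a similar lower number, but two pairs make no rule for the whole series, and they say nothing about why bromo reads lower than chloro or whether the same would hold on a further core.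

The compounds shown leave open how a fluoro, an iodo or a methyl group would read at the place where chloro and bromo sit, which would show whether the trend runs beyond these two halogens. They also leave open whether the step would survive with an amine or a carboxylic acid in place of the nitro group, and whether it would appear in cells other than DU-145.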